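Dimethylphenyl sulfonamides in this series: the 3,4-pattern

The source may report more compounds than this note shows. Statements on the series, on what has been measured and on what is new or still open speak of the compounds shown alone.

Measured so far:
compound 1 `CCc1ccc(NS(=O)(=O)c2ccc(N3CCNC3=O)cc2)cc1`: 660 nM
compound 2 `Cc1cc(C)cc(NS(=O)(=O)c2ccc(N3CCNC3=O)cc2)c1`: 82 nM
compound 3 `Cc1cccc(NS(=O)(=O)c2ccc(N3CCNC3=O)cc2)c1`: 110 nM

In a functional assay on HT-29 cells (Homo sapiens) for antiproliferative activity, read by sulforhodamine B assay, with a stated time of 48 h (on this read-out higher numbers stand for weaker inhibition and lower numbers for stronger inhibition), compound 3 holds the second highest of the three numbers; compound 2 is nearest and within the scatter of it, compound 1 furthest, beyond the scatter. Compound 4 `Cc1ccc(NS(=O)(=O)c2ccc(N3CCNC3=O)cc2)cc1C` differs from compound 3 by methyl in place of hydrogen on an aromatic carbon. Going by the values given here, two measured steps bear on it. The step of a 1.3-fold higher number from compound 2 to compound 3 (0.13 log units; within the scatter) shows that a methyl on an aromatic carbon of the phenyl ring changes nothing beyond the scatter. The steps of an 8.0-fold lower number from compound 1 to compound 2 (0.91 log units; beyond the scatter) and a 6.0-fold lower number from compound 1 to compound 3 (0.78 log units; beyond the scatter) show that the 4-ethylphenyl, whose chain sits para to the large group, gives a clearly higher number than either meta pattern. The entering methyl of compound 4 sits para to the large group too, so a modest rise is expected, smaller than for the ethyl. For compound 4 the expected step is a 2.0-fold higher number from compound 3 to compound 4 (0.30 log units; within the scatter), an estimated 220 nM with a range from 90 nM to 550 nM.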

Compound 4, half-maximal inhibitory concentration: 230 nM
Compound 4: the middle estimate sits 1.0-fold (0.02 log units) below what was measured, within the range that was stated.
By their numbers in this assay, from the lowest: compounds 2 and 3 (each within the scatter of the next); then compound 4; then compound 1.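

In this assay, going by these compounds alone, the methyl para to a large group and ortho to a methyl group gives the first change of methyl pattern on this ring to go beyond the scatter, with a 2.1-fold higher number from compound 3 to compound 4 (0.32 log units; beyond the scatter), while the 3,5-dimethylphenyl and 3-methylphenyl compounds stay within the scatter of each other. With the same two methyl groups on the ring, their placement alone separates two compounds, with a 2.8-fold higher number from compound 2 to compound 4 (0.45 log units; beyond the scatter), and the 3,4-dimethylphenyl still falls short of the rise seen with 4-ethylphenyl, with a 2.9-fold lower number from compound 1 to compound 4 (0.46 log units; beyond the scatter). Nothing available explains why this place behaves differently.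

Open, from the compounds shown here alone, is whether 4-methylphenyl alone, without the 3-methyl, gives a number like that of compound 4. Also open, going by these compounds, is how a methoxy, a chlorine or an amine para to a large group would compare with the methyl.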